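Methoxy to Ethoxy on a Weak Aryl Ether Amine

This account rests on a few compounds, and the source may have more. Where it says the series, first, only, none or still open, it means among the compounds named here.

Measured compounds:
Compound 1 `COc1ccc(OCCOCCNC2CCCC2)cc1`: 99100 nM
Compound 2 `c1ccc(COc2ccc(OCCOCCNC3CCCCC3)cc2)cc1`: 7370 nM

In a functional assay on SK-OV-3 cells (Homo sapiens) for inhibition, read by CCK-8 assay, with a stated time of 70 h (a lower number here means a stronger inhibitor, a higher number a weaker inhibitor), compound 1 gives 99100 nM, the highest of the two numbers recorded. Compound 2 gives 7370 nM in this assay, a lower number that lies beyond the scatter; its structure differs from compound 1 in more than one place, so nothing can be traced to a single change. Compound 3 `CCOc1ccc(OCCOCCNC2CCCC2)cc1` differs from compound 1 by methyl in place of hydrogen on a saturated chain carbon bound to an oxygen on an aromatic ring. Within the data shown here, no measured pair isolates this change. The step from compound 1 to compound 3 is expected to be small, at most a slightly lower number, a 1.4-fold lower number from compound 1 to compound 3 (0.15 log units; within the scatter). Compound 3 is therefore estimated at 70000 nM, within 25000 nM to 200000 nM.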

Compound 3, half-maximal inhibitory concentration: 90500 nM
For compound 3 the middle estimate is 1.3-fold (0.11 log units) below the measured one; low and high end bracket the measured number.
By their numbers in this assay, from the lowest: compound 2; then compounds 3 and 1 (each within the scatter of the next).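

In this assay, among these compounds, the change from methoxy to ethoxy gives a 1.1-fold lower number from compound 1 to compound 3 (0.04 log units; within the scatter), which is the first reading of this change on its own. At this position, on a saturated chain carbon bound to an oxygen on an aromatic ring, one added methyl leaves compound 3 within the scatter of compound 1, so the two cannot be told apart. As far as these compounds go, whether a longer chain such as propoxy, a branched isopropoxy or a terminal hydroxyl would stay equally close remains open. Nothing available gives a reason for this result.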